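The source may hold more compounds than are shown below. What is called first, only, known or untested is meant among the compounds shown, and "the series" means these compounds.

Measured in an assay on cells (Hepatocyte) for inhibition of glucokinase regulatory protein (Mus musculus), with stated times of 20 min and 40 min; on this read-out lower numbers stand for an effect already at smaller amounts and higher numbers for an effect only at larger amounts of compound:
compound 1 `CC#C[C@H]1CN(S(=O)(=O)c2ccc(N)nc2)CCN1c1ccc(C(O)(COC)C(F)(F)F)cc1` gives 202 nM
compound 2 `CC#C[C@H]1CN(S(=O)(=O)c2ccc(N)nc2)CCN1c1ccc(S(=O)(=O)NCC2CC2)cc1` gives 271 nM
compound 3 `CC#C[C@H]1CN(S(=O)(=O)c2ccc(N)nc2)CCN1c1ccc(S(N)(=O)=O)cc1` gives 37 nM

Compound 1 stands second highest of the three numbers. Its nearest neighbour is compound 2, with a 1.3-fold higher number from compound 1 to compound 2 (0.13 log units; within the scatter), and its furthest is compound 3, with a 5.5-fold lower number from compound 1 to compound 3 (0.74 log units; beyond the scatter). Compound 4 `CC#C[C@H]1CN(S(=O)(=O)c2ccc(N)nc2)CCN1c1ccc(C(C)=O)cc1` is not yet measured and differs from compound 1 in one place: a group of 3 heavy atoms (2 carbon, 1 oxygen; no ring) in place of a group of 9 heavy atoms (4 carbon, 2 oxygen, 3 fluorine; no ring), on an aromatic carbon. Among the measured compounds shown here, no measured step exchanges the leaving group for acetyl. For the measured compounds named here, the steps that bear on it are those in which the group on this aromatic carbon becomes smaller, a 5.5-fold lower number from compound 1 to compound 3 (0.74 log units; beyond the scatter) and a 7.3-fold lower number from compound 2 to compound 3 (0.86 log units; beyond the scatter), both going to a lower number, whereas a 1.3-fold higher number from compound 1 to compound 2 (0.13 log units; within the scatter), an exchange between two groups of similar size, stays within the scatter. The entering acetyl is small, but it carries no hydrogen-bond donor where the leaving group has one, so the size of the step is uncertain. Given a 5.5-fold lower number from compound 1 to compound 3 (0.74 log units; beyond the scatter), a step of a 2.2-fold lower number from compound 1 to compound 4 (0.35 log units; beyond the scatter) is expected. For compound 4 the estimate in this assay is 90 nM, with a range of 30 nM to 300 nM.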

Compound 4, half-maximal effective concentration: > 12500 nM
Compound 4 was reported as a limit; the forecaster's own chance of this, stated with the estimate: 3%; at least 130-fold (2.14 log units) between middle value and limit.
By their numbers in this assay, from the lowest: compound 3; then compounds 1 and 2 (each within the scatter of the next). At a limit, above all of these: compound 4.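

In this assay compound 4 is reported only as a limit, not as a number: the limit of > 12500 nM in this assay, at which 1 of the 4 values shown sits. The earlier trend of a lower number with a smaller group on this aromatic carbon does not hold generally, and compound 4 goes against it: although sulfamoyl and acetyl are both small, the exchange gives an at least 330-fold higher number from compound 3 to compound 4 (2.52 log units; beyond the scatter). The larger groups also differ sharply from acetyl, with an at least 61-fold higher number from compound 1 to compound 4 (1.79 log units; beyond the scatter) and an at least 46-fold higher number from compound 2 to compound 4 (1.66 log units; beyond the scatter), so group size alone does not describe this position.

Acetyl has 0 hydrogen-bond donors and the group it replaces in compound 1 has 1, but these compounds cannot separate the missing donor from the presence of the carbonyl or any other difference. From the compounds shown here alone, whether a hydroxymethyl group or a primary amide on this carbon would restore a measurable number remains open.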